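From Compound 3 to Compound 4: a Ring Change

The compounds below may be only part of what the source reports. "The series", "measured", "known", "first", "only" and "open" are said of these compounds alone.

Compound 1 `O=C1C=COC(/C=C/c2ccc(C(F)(F)F)cc2)C1` gives 123 uM in an ADME assay on HaCaT cells (Homo sapiens) for inhibition, read by sulforhodamine B assay, with a stated time of 48 h; a higher number here means a weaker inhibitor of growth, a lower number a stronger inhibitor of growth.
Compound 2 `COc1ccc(/C=C/C2CC(=O)C=CO2)cc1OC` gives 134 uM.
Compound 3 `COc1cc(/C=C/C2CC(=O)C=CO2)cc(OC)c1OC` gives 155 uM.

Compound 3 stands at the highest of the three numbers, yet its gaps to compound 2 and to compound 1 both lie within the scatter, so the three are indistinguishable here. Going by the values given here, the single measured step, a 1.2-fold higher number from compound 2 to compound 3 (0.06 log units; within the scatter), is likewise within the scatter.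

Compound 4 `COc1cc(/C=C/C2CC=CC(=O)N2)cc(OC)c1OC` differs from compound 3 by a group of 7 heavy atoms (5 carbon, 1 nitrogen, 1 oxygen; one six-membered non-aromatic ring with 1 hetero atom) in place of a group of 7 heavy atoms (5 carbon, 2 oxygen; one six-membered non-aromatic ring with 1 hetero atom), on a double-bonded chain carbon bound to a double-bonded chain carbon. Among the compounds with values here, no measured step involves this kind of change; the step from methoxy for hydrogen bears on it only by showing that the series so far is flat. The step is therefore expected to stay within the scatter, a 1.0-fold lower number from compound 3 to compound 4 (0.01 log units; within the scatter). Compound 4 is estimated at 150 uM, with a range of 60 uM to 400 uM.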

Compound 4, concentration for growth inhibition (reported as GI): > 864 uM
Compound 4 gave a limit, no number; the forecaster's own chance of this, stated with the estimate: 20%; middle value at least 5.7-fold (0.76 log units) away from the limit.
By their numbers in this assay, from the lowest: compounds 1, 2 and 3 (each within the scatter of the next). At a limit, above all of these: compound 4.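

In this assay, going by these compounds alone, the ring change on a double-bonded chain carbon bound to a double-bonded chain carbon gives an at least 5.5-fold higher number from compound 3 to compound 4 (0.74 log units; beyond the scatter), the first step that lies beyond the scatter. The earlier compounds shown here looked flat, but this position responds even though both groups are six-membered non-aromatic rings with 1 hetero atom and 7 heavy atoms. Compound 4 gave a limit and not a number: the limit of > 864 uM in this assay, at which 1 of the 4 values shown sits.

Going by these compounds, how far compound 4 lies past that limit stays open. So does whether a ring with sulfur as its hetero atom would read like compound 3 or like compound 4.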